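The source may report more compounds than this note shows. Statements on the series, on what has been measured and on what is new or still open speak of the compounds shown alone.

Compound 1 (`COc1cccc(-c2nc3c(c(C)nn3-c3ccccc3)c(-c3ccccc3O)c2C#N)c1`): > 23000 nM (a limit)
Compound 2 (`Cc1cccc(-c2nc3c(c(C)nn3-c3ccccc3)c(-c3ccccc3O)c2C#N)c1`): > 20000 nM (a limit)

In an ADME assay on BJ cells (Homo sapiens) for cytotoxicity, with a stated time of 72 h (on this read-out lower numbers stand for an effect already at smaller amounts and higher numbers for an effect only at larger amounts of compound), compound 2 gives > 20000 nM as its result, which is a limit and not a number. Compound 1 likewise gives > 23000 nM as a limit. Neither compound therefore has an exact value to build on.

Compound 3 (`Cc1ccccc1-c1nc2c(c(C)nn2-c2ccccc2)c(-c2ccccc2O)c1C#N`) has the same atoms as compound 2, joined differently. The change is 2-methylphenyl in place of 3-methylphenyl on an aromatic carbon and it falls on the aromatic carbon next to the ring nitrogen and ortho to a cyano group. Going by the values given here, the one measured step that bears on it is a step that the two limits leave unreadable from compound 1 to compound 2 and it concerns the group at this same place. It offers no size to carry over, so the expected step that the limit leaves unreadable from compound 2 to compound 3 is none beyond the usual scatter in this assay and has no expected direction. Among the compounds with values here, the only guide is compound 2, with its limit of > 20000 nM as the reference point. Another limit is therefore the likeliest report. For compound 3 the estimate is 25000 nM with an expected range from 12000 nM to 50000 nM in this test.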

Compound 3, half-maximal effective concentration: 21000 nM
Compound 3: middle estimate off by 1.2-fold (0.08 log units), on the high side; the range from low to high includes it.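

In this assay, going by these compounds alone, compound 3 gives 21000 nM, the first exact number for this position, the aromatic carbon next to the ring nitrogen and ortho to a cyano group, and here it belongs to the 2-methylphenyl group. Replacing the 3-methoxyphenyl group of compound 1 with 2-methylphenyl gives an at least 1.0-fold lower number from compound 1 to compound 3 (0.03 log units; that floor lies within the scatter), so this change shows no difference that can be told apart from the ordinary spread of repeated measurements. Compound 2 gives only a limit, and the steps that rest on it cannot be read because a limit supplies no size: the limit of > 20000 nM in this assay, at which 1 of the 3 values shown sits.

From the compounds shown here alone, whether moving the methyl between 3-methylphenyl and 2-methylphenyl changes the read-out at all therefore stays open. All three compounds carry a phenyl ring with a small group at this position, and the compounds shown do not tell what an amine or a carboxylic acid on that ring would do, or what a longer chain in place of the ring would do.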